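The source may report more compounds than this note shows. Statements on the series, on what has been measured and on what is new or still open speak of the compounds shown alone.

Measured so far in an assay on isolated protein for inhibition of thyroid hormone receptor alpha (Homo sapiens), read by fluorescence polarization; on this read-out higher numbers stand for weaker inhibition and lower numbers for stronger inhibition:
compound 1 `CN(Cc1ccccc1)C(=O)C1CCN(C(=O)c2ccc(S(C)(=O)=O)c([N+](=O)[O-])c2)CC1` — > 60000 nM (a limit of the assay)
compound 2 `CS(=O)(=O)c1ccc(C(=O)NCC(=O)N(Cc2ccccc2)Cc2ccccc2)cc1[N+](=O)[O-]` — 1700 nM
compound 3 `CN(Cc1ccccc1)C(=O)CNC(=O)c1ccc(S(C)(=O)=O)c([N+](=O)[O-])c1` — > 60000 nM (a limit of the assay)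

Compound 3 sits at the limit of > 60000 nM in this assay, at which 2 of the 3 values shown sit. Compound 1 sits at the same limit. Compound 3 and compound 2 differ by phenyl in place of hydrogen on a saturated chain carbon bound to an amide-type nitrogen; this change gives an at least 35-fold lower number from compound 3 to compound 2 (1.54 log units; beyond the scatter). Compound 1 and compound 3 have cores whose difference is not broken down here. Compound 4 `CS(=O)(=O)c1ccc(C(=O)N2CCC(C(=O)N(Cc3ccccc3)Cc3ccccc3)CC2)cc1[N+](=O)[O-]`, not yet measured, differs from compound 1 by phenyl in place of hydrogen on a saturated chain carbon bound to an amide-type nitrogen, the same change as from compound 3 to compound 2. Since compound 1 gives only a limit, the size of the step cannot be fixed; the expected step in this assay is an at least 10-fold lower number from compound 1 to compound 4 (1.00 log units; beyond the scatter), resting on compound 3 to compound 2. Compound 4 is estimated at 6000 nM, with a plausible range of 1000 nM to 60000 nM.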

Compound 4, half-maximal inhibitory concentration: > 60000 nM
Compound 4 was reported as a limit; the forecaster's own chance of this, stated with the estimate: 30%; middle value at least 10-fold (1.00 log units) from the limit.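

Among the compounds shown here, compound 1 and compound 4 are both reported only as limits, and no step between them can be read. The compounds shown leave open whether the phenyl change has any effect on the core of compound 1.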